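Trimethoxyphenyl for methoxyphenyl in a pyrazoline series

The source may hold more compounds than are shown below. What is called first, only, known or untested is meant among the compounds shown, and "the series" means these compounds.

Compound 1 `COc1ccc(C2=NN(C(=O)c3cccnc3)C(c3cn(C)c4ccc(Br)cc34)C2)cc1` gives 1560 nM in a functional assay on MCF7 cells (Homo sapiens) for inhibition, read by MTT assay, with a stated time of 48 h; a higher number here means a weaker inhibitor of growth, a lower number a stronger inhibitor of growth. Compound 2 `COc1cc(C2=NN(C(=O)c3cccnc3)C(c3cn(C)c4ccc(Br)cc34)C2)cc(OC)c1OC` reaches only a limit of the assay, > 10000 nM. The change between them, (3,4,5-trimethoxyphenyl in place of 4-methoxyphenyl on a carbon with a double bond to nitrogen), made a step of an at least 6.4-fold higher number from compound 1 to compound 2 (0.80 log units; beyond the scatter); the size of that step cannot be fixed more closely because of the limit of > 10000 nM in this assay, at which 1 of the 3 values shown sits. Compound 3 `COc1ccc(C2=NN(C(=O)c3ccc(OC)nc3)C(c3cn(C)c4ccc(OC)cc34)C2)cc1` gives 560 nM in this assay, the lowest of the two numbers given, with compound 1 as its nearest neighbour. The difference between the cores of compound 1 and compound 3 is not broken down here.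

Compound 4 `COc1ccc2c(c1)c(C1CC(c3cc(OC)c(OC)c(OC)c3)=NN1C(=O)c1ccc(OC)nc1)cn2C` has not yet been measured in this assay. It differs from compound 3 by 3,4,5-trimethoxyphenyl in place of 4-methoxyphenyl on a carbon with a double bond to nitrogen. This is the same kind of change as from compound 1 to compound 2, though the surroundings differ: in compound 3 the ring atom two bonds away bears a (6-methoxypyridin-3-yl)carbonyl group rather than a (pyridin-3-yl)carbonyl group. The step for compound 4 is expected at about an 11-fold higher number from compound 3 to compound 4 (1.03 log units; beyond the scatter), resting on the step from compound 1 to compound 2, an at least 6.4-fold higher number from compound 1 to compound 2 (0.80 log units; beyond the scatter). The expected value for compound 4 is 6000 nM, between 2000 nM and 20000 nM.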

Compound 4, concentration for 50% growth inhibition: > 10000 nM
Compound 4 gave a limit, no number; the forecaster's own chance of this, stated with the estimate: 45%; at least 1.6-fold (0.22 log units) between middle value and limit.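

Compound 4 reaches only a limit of this assay, > 10000 nM, and this is not a number. Replacing 4-methoxyphenyl with 3,4,5-trimethoxyphenyl gives an at least 17-fold higher number from compound 3 to compound 4 (1.25 log units; beyond the scatter), so the direction of the change carries over from the core of compound 1 to the core of compound 3, with weaker growth inhibition on both: the same change on two cores in this assay, an at least 6.4-fold higher number (0.80 log units; beyond the scatter) from compound 1 to compound 2 and an at least 17-fold higher number (1.25 log units; beyond the scatter) from compound 3 to compound 4; the limit leaves it open whether they differ This does not show whether the size of the step is the same on the two cores, and no ranking of the two steps can be made, because the trimethoxyphenyl compounds give no number: the limit of > 10000 nM in this assay, at which 2 of the 4 values shown sit.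

The compounds shown leave open whether the loss follows the number of methoxy groups on the phenyl ring or belongs to the 3,4,5-trimethoxyphenyl group as a whole, which a 3,4-dimethoxyphenyl group at the same place could help to separate. They also leave open how a phenyl ring bearing an amine or a carboxylic acid would behave there.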